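The source may report more compounds than this note shows. Statements on the series, on what has been measured and on what is new or still open speak of the compounds shown alone.

Compound 1 `COC1=C(OC)C(=O)C(CCCCCCCCCCN=[N+]=[N-])=C(C)C1=O` and compound 2 `CCCCCCCCCCCCCCCC1=C(C)C(=O)C(OC)=C(OC)C1=O` share one core and differ in one group on a saturated chain carbon of the chain. In a functional assay on CCRF-CEM cells (Homo sapiens) for cytotoxicity, read by trypan blue exclusion, with stated times of 17 h and 6 h, tested at 1 uM (on this read-out lower numbers stand for a weaker effect and higher numbers for a stronger effect at the one concentration tested), compound 1 gives 72%, while compound 2 gives 90%; the step between them is a number 18 percentage points higher from compound 1 to compound 2 (beyond the scatter). Compound 2 therefore stands highest of the two numbers, with compound 1 as its nearest neighbour, lower by that step. Compound 3 `COC1=C(OC)C(=O)C(CCCCCCCCC(C)(C)C)=C(C)C1=O` keeps the shared core but alters the chain: tert-butyl in place of heptyl on a saturated chain carbon, eight bonds along the chain from a double-bonded ring carbon. Going by the values given here, only one measured step exists, and it also changed a group on the chain, giving a modest rise; nothing measured yet covers a shorter, branched chain. On this thin basis the change is expected to be small, perhaps within the scatter, as a number 8 percentage points lower from compound 2 to compound 3 (within the scatter) expresses. Compound 3 is estimated at 82% in this assay, with a range from 62% to 95%.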

Compound 3, a percentage reported as activity, at one concentration (the size of the read-out at that concentration, not a potency): 72%
Compound 3: middle estimate off by 10 percentage points, on the high side; the measured number falls inside the stated range.
By their numbers in this assay, from the lowest: compounds 1 and 3 (each within the scatter of the next); then compound 2.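

In this assay, tert-butyl in place of heptyl on a saturated chain carbon, eight bonds along the chain from a double-bonded ring carbon, gives a number 18 percentage points lower from compound 2 to compound 3 (beyond the scatter), so the end of the chain counts for this read-out. Two very different chain ends, tert-butyl and 2-azidoethyl, then sit level, with no change at the digits printed from compound 1 to compound 3 (within the scatter), which leaves the long unbranched chain of compound 2 alone at the top of these compounds. Nothing shown here explains the difference.

The compounds shown do not separate chain length from branching, which change together in compound 3. From the compounds shown here alone, an unbranched butyl group at this place would bear on that question, and how an amine or a carboxylic acid there would read stays open.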